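The source may report more compounds than this note shows. Statements on the series, on what has been measured and on what is new or still open speak of the compounds shown alone.

Of the compounds shown here, two sharing one core have been measured in an assay on membranes from liver for displacement of a labelled ligand from Sigma intracellular receptor 2 (Rattus norvegicus), read by scintillation counting, with a stated time of 120 min; a lower number here means a stronger inhibitor, a higher number a weaker inhibitor. Compound 1 `COc1ccc(CN2CCCN(Cc3ccccc3)[C@@H](C)C2)cc1` gives 46 nM, the lowest of the two numbers. Compound 2 `COc1ccc(CN2CCCN(Cc3ccccc3)[C@H](C)C2)cc1` has the same atoms and bonds and differs only in the configuration drawn at one saturated ring carbon; compound 2 gives 431 nM. The step of a 9.4-fold higher number from compound 1 to compound 2 (0.97 log units; beyond the scatter) lies beyond the scatter, and the only pointer to its cause is the fact that compounds 1 and 2 differ only in the configuration as drawn. Compound 3 `COc1ccc(CN2CCCN(Cc3ccccc3)[C@@H](C(C)C)C2)cc1` keeps the configuration of compound 1 and differs from it by isopropyl in place of methyl on a saturated ring carbon, an isopropyl in place of methyl on a saturated ring carbon. Among the measured compounds shown here, no measured step changes a group at that carbon; the single measured step shows only that the configuration there matters. The expected step is therefore modest, with no clear direction: a 1.7-fold higher number from compound 1 to compound 3 (0.24 log units; within the scatter). Compound 3 is estimated to give about 80 nM in this assay, within a range from 20 nM to 400 nM.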

Compound 3, inhibition constant: > 1000 nM
Compound 3: only a limit was reported; the forecaster's own chance of this, stated with the estimate: 3%; middle value at least 12-fold (1.09 log units) from the limit.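

In this assay compound 3 gives > 1000 nM, which is a limit of the assay and not a number. Among the compounds shown here, until now, the only measured change at this saturated ring carbon was its configuration; this result shows that the group it carries matters as well, with isopropyl in place of methyl giving an at least 21-fold higher number from compound 1 to compound 3 (1.33 log units; beyond the scatter). How much larger the true step is cannot be read from this result: the limit of > 1000 nM in this assay, at which 1 of the 3 values shown sits.

The compounds shown leave open how an ethyl group or a hydroxymethyl group would behave at this carbon, and so whether the number climbs gradually or jumps sharply on going from methyl to isopropyl. They also leave open why isopropyl gives this result, and whether isopropyl drawn in the configuration of compound 2 would behave in the same way.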